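Amide series: isopropyl in place of cyclopropyl on the carbonyl

The source may hold more compounds than are shown below. What is called first, only, known or untested is meant among the compounds shown, and "the series" means these compounds.

Measured compounds:
compound 1, `COc1ccc(CN(C(=O)C2CC2)c2cc(OC)c(OC)c(OC)c2)cc1O`: 49 nM
compound 2, `C/C=C/C(=O)N(Cc1ccc(OC)c(C)c1)c1cc(OC)c(OC)c(OC)c1`: 23500 nM
compound 3, `COc1ccc(CNc2cc(OC)c(OC)c(OC)c2)cc1N`: 8270 nM

The three values come from a functional assay on HCT-116 cells (Homo sapiens) for inhibition, read by MTT assay, with a stated time of 48 h; on this read-out lower numbers stand for stronger inhibition and higher numbers for weaker inhibition. Compound 1 stands lowest of the three numbers. Its nearest neighbour is compound 3, whose value of 8270 nM lies beyond the scatter above it; the furthest is compound 2, whose value of 23500 nM lies further still. For the measured compounds named here, neither compound 2 nor compound 3 differs from compound 1 in a single place, so no step between measured compounds isolates any one change, and nothing in the set speaks to the substituent on the carbonyl carbon.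

The next compound, compound 4, `COc1ccc(CN(C(=O)C(C)C)c2cc(OC)c(OC)c(OC)c2)cc1O`, differs from compound 1 in one place: isopropyl in place of cyclopropyl on a carbonyl carbon. The group that leaves and the group that enters carry the same count of heavy atoms, donors and acceptors; only the three-membered ring is lost.

Going by the values given here, with no measured step on this change, the expectation in this assay is a small step from compound 1 to compound 4, in either direction, most likely within the scatter. Compound 4 is therefore expected near 70 nM, within 25 nM to 200 nM, an estimated step of a 1.4-fold higher number from compound 1 to compound 4 (0.15 log units; within the scatter).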

Compound 4, half-maximal inhibitory concentration: 310 nM
Compound 4: middle estimate off by 4.4-fold (0.65 log units), on the low side, and the stated range ends below it.
By their numbers in this assay, from the lowest: compound 1; then compound 4; then compound 3; then compound 2.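

In this assay, the group on the carbonyl carbon proves to matter: isopropyl in place of cyclopropyl gives a 6.3-fold higher number from compound 1 to compound 4 (0.80 log units; beyond the scatter), a step beyond the usual scatter and the first in this series that isolates a single change. Both groups have the same count of heavy atoms, donors and acceptors. Cyclopropyl has a three-membered ring and isopropyl has no ring, and for this pair the cyclopropylcarbonyl amide is the stronger inhibitor. The compounds at hand carry no measurement that would account for this step.

This single pair cannot tell whether the preference belongs to the three-membered ring specifically or extends to other groups on the carbonyl carbon, such as cyclobutyl, ethyl or tert-butyl, so the step does not yet define a trend for this place. For the compounds shown here, it also remains open whether a step of this size would recur on a core with a different substitution pattern from that shared by compound 1 and compound 4, since only this one pair speaks to the change.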